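Trimming the amide substituent: compound 1 to compound 4

This account rests on a few compounds, and the source may have more. Where it says the series, first, only, none or still open, it means among the compounds named here.

Compound 1 (`Nc1c(C(=O)N/N=C/c2ccc(Br)cc2)oc2nc(-c3cccs3)cc(C(F)(F)F)c12`) gives 86000 nM in an ADME assay on HEK293 cells (Homo sapiens) for antiproliferative activity, read by MTT assay (a higher number here means a weaker inhibitor, a lower number a stronger inhibitor), and so sits within the scatter of compound 2 (`CNC(=O)c1oc2nc(-c3ccccc3)cc(C(F)(F)F)c2c1N`) at 62000 nM and of compound 3 (`Nc1c(C(=O)N/N=C/c2ccc(Cl)cc2)oc2nc(-c3ccccc3)cc(C(F)(F)F)c12`) at 81000 nM as well. None of the three stands apart from the others on these numbers.

The change to compound 4 (`CCNC(=O)c1oc2nc(-c3cccs3)cc(C(F)(F)F)c2c1N`) is a group of 2 heavy atoms (2 carbon; no ring) in place of a group of 9 heavy atoms (7 carbon, 1 nitrogen, 1 bromine; one six-membered aromatic ring of carbon only), on an amide-type nitrogen and the core of compound 1 stays as it is. Ethyl enters on the amide-type nitrogen, and the group with the six-membered aromatic ring of carbon only leaves.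

For the measured compounds named here, one measured step bears on this change, and it concerns the same amide-type nitrogen. It runs the opposite way, with a group of 9 heavy atoms in place of one carbon atom. Going by the values given here, compound 2 and compound 3 also carry a different group on the core than compound 1 does, and no such pair has been measured on the core of compound 1, so the transfer remains uncertain.

Given a 1.3-fold higher number from compound 2 to compound 3 (0.12 log units; within the scatter) on that nitrogen, no shift beyond the scatter is expected in this assay here. The expected step is a 1.2-fold lower number from compound 1 to compound 4 (0.09 log units; within the scatter) and this estimated shift, slightly toward a lower number if real, stays within the scatter. For compound 4 the estimated value is 70000 nM with an expected range from 38000 nM to 125000 nM in this read-out.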

Compound 4, half-maximal inhibitory concentration: 62000 nM
Compound 4: the middle estimate sits 1.1-fold (0.05 log units) above what was measured, within the range that was stated.
By their numbers in this assay, from the lowest: compounds 2, 4, 3 and 1 (each within the scatter of the next).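

On the core of compound 1, the amide-type nitrogen now has a measured pair of its own: in this assay, ethyl in place of the group with the six-membered aromatic ring of carbon only gives a 1.4-fold lower number from compound 1 to compound 4 (0.14 log units; within the scatter) and so removes the need to carry the reading over from another core. Together with a 1.3-fold higher number from compound 2 to compound 3 (0.12 log units; within the scatter) on the same nitrogen, this gives two pairs on two different cores, both within the scatter. In these two pairs, a group of 9 heavy atoms and a far smaller one on this nitrogen cannot be told apart in this read-out, and the double bond outside aromatic rings and the bromine that leave with the larger group produce no step beyond the scatter.

Nothing at hand gives a reason for this lack of separation.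

As far as these compounds go, whether any group on the amide-type nitrogen can move the number beyond the scatter stays open, for example a longer chain such as butyl, a carboxylic acid or a primary amine. The unsubstituted amide, with only hydrogen on that nitrogen, is also absent from the compounds shown, so the lower end of this size range stays undefined on either core.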